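Methoxy to methyl on the anilide ring of compound 3

The source may hold more compounds than are shown below. What is called first, only, known or untested is meant among the compounds shown, and "the series" means these compounds.

Compound 1, `CCNC(=O)c1nc(-c2cc(OC)c(OC)c(OC)c2)n(-c2ccc(OC)cc2)n1`: 88%
Compound 2, `COc1ccc(NC(=O)c2nc(-c3cc(OC)c(OC)c(OC)c3)n(-c3ccc(OC)cc3)n2)cc1`: 86%
Compound 3, `COc1ccc(-n2nc(C(=O)Nc3ccccc3OC)nc2-c2cc(OC)c(OC)c(OC)c2)cc1`: 38%

Three amides sharing one core were tested in a functional assay on the whole organism for inhibition, with Rattus norvegicus as the target, read by paw edema, with stated times of 30 min and 3 h, at a dose of 0.28 mmol/kg by the oral route; a lower number here means less inhibition, a higher number more inhibition at the dose given (going by the name of the read-out). Compound 1 and compound 2 sit close together, a pair within the scatter (a number 2 percentage points lower from compound 1 to compound 2 (within the scatter)). Compound 3 stands lowest of the three: a number 50 percentage points lower from compound 1 to compound 3 (beyond the scatter) and a number 48 percentage points lower from compound 2 to compound 3 (beyond the scatter) are both large and beyond the scatter.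

Compound 4, `COc1ccc(-n2nc(C(=O)Nc3ccccc3C)nc2-c2cc(OC)c(OC)c(OC)c2)cc1`, is not yet measured. It differs from compound 3 in one place: methyl in place of methoxy on an aromatic carbon. Among the measured compounds shown here, no measured pair shows this exchange; the two large steps both concern what sits on the amide-type nitrogen, not a change on the ring that stays. For the measured compounds named here, they therefore say only that the number of compound 3 is the lowest of the three, not how a methyl in place of methoxy would move it. Going by the values given here, with no step to go by, compound 4 is expected to stay near compound 3, and the estimated step of a number 6 percentage points higher from compound 3 to compound 4 (within the scatter) is not expected to exceed the scatter. Compound 4 is estimated at 44%, within 25% to 68%.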

Compound 4, a percentage reported as inhibition, in the whole organism at one dose (the size of the read-out at that dose, not a potency): 64%
For compound 4 the middle estimate is 20 percentage points below the measured one; the range from low to high includes it.
By their numbers in this assay, from the lowest: compound 3; then compound 4; then compounds 2 and 1 (each within the scatter of the next).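

In this assay, the group on this aromatic carbon, ortho to a large group, matters: methyl in place of methoxy gives a number 26 percentage points higher from compound 3 to compound 4 (beyond the scatter) and so the low number of compound 3 is tied to the methoxy itself, not merely to having some group at this place. The 2-methylphenyl amide still does not match the other two amides, with a number 22 percentage points lower from compound 2 to compound 4 (beyond the scatter) and a number 24 percentage points lower from compound 1 to compound 4 (beyond the scatter) showing that this exchange closes only part of the gap left by 2-methoxyphenyl. Nothing available explains the step.

The compounds shown leave open how a chlorine, an ethyl or a hydroxyl at this same place would compare with methyl and methoxy. They also leave open whether a 4-methylphenyl amide would stand with compound 2 or with compound 4.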